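The source may hold more compounds than are shown below. What is called first, only, known or untested is meant among the compounds shown, and "the series" means these compounds.

Measured so far:
compound 1, `COc1ccc(Cl)cc1-c1cc(Nc2ccc(Cl)cc2)nc(N)n1`: 54 nM
compound 2, `CCOc1ccc(Cl)cc1-c1cc(Nc2ccc(Cl)cc2)nc(N)n1`: 17 nM

Both numbers come from an assay on Sf9 cells for inhibition of 1-acyl-sn-glycerol-3-phosphate acyltransferase beta (Homo sapiens); on this read-out higher numbers stand for weaker inhibition and lower numbers for stronger inhibition. Among the measured compounds shown here, compound 2 stands lowest of the two, and the only measured step, a 3.2-fold lower number from compound 1 to compound 2 (0.50 log units; beyond the scatter), is beyond the scatter. It replaces a hydrogen with a methyl on the chain carbon that sits on the oxygen of the aromatic ring, and it concerns a different part of the molecule from the change that leads to compound 3.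

Compound 3, `CCOc1ccc(Cl)cc1-c1cc(Nc2ccc(CCCO)cc2)nc(N)n1`, has not yet been measured. It differs from compound 2 in one place: 3-hydroxypropyl in place of chloro on an aromatic carbon. For the measured compounds named here, no measured step touches this position, so nothing measured speaks for or against the exchange; the one known step only shows that the shared core tolerates a small change elsewhere.

Going by the values given here, with no precedent, compound 3 is expected to stay near compound 2, with an estimated step of a 2.4-fold higher number from compound 2 to compound 3 (0.37 log units; beyond the scatter) in this assay. The estimate for compound 3 is 40 nM, within a wide range from 8 nM to 200 nM.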

Compound 3, half-maximal inhibitory concentration: 230 nM
Beside the measured number, compound 3's estimate is 5.8-fold (0.76 log units) below it; measured number outside the range, above it.
By their numbers in this assay, from the lowest: compound 2; then compound 1; then compound 3.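

The exchange of chloro for 3-hydroxypropyl, on an aromatic carbon para to a large group, gives a 14-fold higher number from compound 2 to compound 3 (1.13 log units; beyond the scatter) in this assay, a large step and the only one shown at this position. It shows that this position is far from indifferent: replacing a single chlorine atom with a chain of 4 heavy atoms that carries a hydrogen-bond donor and acceptor markedly weakens inhibition, although compound 3 still gives a measurable 230 nM. Nothing available explains why this exchange has so large an effect.

The single step changes the size of the group and adds the hydroxyl at the same time, so the compounds shown leave open whether the carbon chain, its oxygen or simply the loss of chlorine drives the result. A plain propyl group would help to separate these parts, while a hydroxymethyl group, a longer chain or an amine at the end of the chain would show how much the length and the end group of the chain matter here.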